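Lengthening the acid chain of compound 2

The source may report more compounds than this note shows. Statements on the series, on what has been measured and on what is new or still open speak of the compounds shown alone.

In a functional assay on MDA-MB-231 cells (Homo sapiens) for cytotoxicity, read by MTT assay, with a stated time of 48 h (a lower number here means a stronger inhibitor, a higher number a weaker inhibitor), compound 2 `O=C(O)CN1C(=O)/C(=C/c2nc3ccccc3n2Cc2ccccc2F)SC1=S` gives 330 nM, the lowest number in this small series. Compound 1 `O=C(O)CN1C(=O)/C(=C/c2nc3ccccc3n2Cc2ccc(F)cc2)SC1=S` gives 2620 nM. Compound 3 `O=C(O)CN1C(=O)/C(=C/c2nc3ccc(F)cc3n2Cc2ccccc2F)SC1=S` reads > 50000 nM, which is a limit of the assay. Compound 4 `O=C(O)CCN1C(=O)/C(=C/c2nc3ccccc3n2Cc2ccccc2F)SC1=S` carries carboxymethyl in place of carboxy on a saturated chain carbon bound to an amide-type nitrogen in a ring, so carboxymethyl becomes 2-carboxyethyl. Neither measured step touches this place, and they bear on it only indirectly. They were a 7.9-fold lower number from compound 1 to compound 2 (0.90 log units; beyond the scatter) and an at least 150-fold higher number from compound 2 to compound 3 (2.18 log units; beyond the scatter), so single changes here have moved this assay strongly. A modest rise is expected, a 2.4-fold higher number from compound 2 to compound 4 (0.38 log units; beyond the scatter), with wide uncertainty. Compound 4 is estimated at 800 nM, within 170 nM to 5000 nM.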

Compound 4, half-maximal inhibitory concentration: 9530 nM
The estimate for compound 4 lay 12-fold (1.08 log units) below the measured number, and the stated range ends below it.
By their numbers in this assay, from the lowest: compound 2; then compound 1; then compound 4. At a limit, above all of these: compound 3.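

Compounds 1 and 3 changed other parts of the molecule, so the acid chain on the amide-type nitrogen had not yet been tested. In this assay this position proves sensitive to chain length: with the carboxylic acid kept, 2-carboxyethyl in place of carboxymethyl gives a 29-fold higher number from compound 2 to compound 4 (1.46 log units; beyond the scatter) on this one change. The data shown offer no reason for this loss.

Still open, from the compounds shown here alone, is whether a longer chain would raise the number further. Going by these compounds, it is also open whether an ester or an amine at the end of the chain would keep the number of compound 2.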